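The source may hold more compounds than are shown below. What is called first, only, known or untested is meant among the compounds shown, and "the series" means these compounds.

Compound 1 `COc1cc2c(Oc3ccc(NC(=O)/C=C/S(=O)(=O)c4ccccc4F)cc3F)ccnc2cc1OCCCN1CCN(C)CC1` — 150 nM
Compound 2 `COc1cc2c(Oc3ccc(NC(=O)/C=C/S(=O)(=O)c4ccccc4OC)cc3F)ccnc2cc1OCCCN1CCN(C)CC1` — 320 nM
Compound 3 `COc1cc2c(Oc3ccc(NC(=O)/C=C/S(=O)(=O)c4ccc(C)cc4)cc3F)ccnc2cc1OCCCN1CCN(C)CC1` — 1510 nM

In a functional assay on A549 cells (Homo sapiens) for cytotoxicity, read by MTT assay, with a stated time of 72 h (a lower number here means a stronger inhibitor, a higher number a weaker inhibitor), compound 2 stands second highest of these three numbers. The neighbouring steps are a 2.1-fold higher number from compound 1 to compound 2 (0.33 log units; beyond the scatter) and a 4.7-fold higher number from compound 2 to compound 3 (0.67 log units; beyond the scatter); the remaining step is a 10-fold higher number from compound 1 to compound 3 (1.00 log units; beyond the scatter). All three steps change the aryl on the sulfonyl sulfur.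

Compound 4 `COc1cc2c(Oc3ccc(NC(=O)/C=C/S(=O)(=O)c4ccccc4OC)cc3F)ccnc2cc1OCCCN1CCCCC1` differs from compound 2 in another place: piperidin-1-yl in place of 4-methylpiperazin-1-yl on a saturated chain carbon, three bonds along the chain from an oxygen on an aromatic ring. Within the data shown here, no measured step touches this position, so none of them bears on the change, and nothing in the measured series speaks for a shift in either direction. Compound 4 is therefore expected to show no step beyond the scatter, no change at the digits printed from compound 2 to compound 4 (within the scatter). Compound 4 is estimated at 320 nM, with a range from 120 nM to 850 nM.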

Compound 4, half-maximal inhibitory concentration: 470 nM
For compound 4 the middle estimate is 1.5-fold (0.17 log units) below the measured one; the measured number falls inside the stated range.
By their numbers in this assay, from the lowest: compound 1; then compounds 2 and 4 (each within the scatter of the next); then compound 3.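

In this assay, piperidin-1-yl in place of 4-methylpiperazin-1-yl at the end of the propyl chain gives a 1.5-fold higher number from compound 2 to compound 4 (0.17 log units; within the scatter), the only step shown at this position. With 2-methoxyphenyl on the sulfonyl sulfur, then, the second ring nitrogen and its methyl can go without a step beyond the scatter. No measured evidence bears on why this is so. From the compounds shown here alone, whether the same holds with the 2-fluorophenyl of compound 1 remains open. So does the outcome with a morpholine ring or a dimethylamino group at the chain end.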